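The source may hold more compounds than are shown below. What is called first, only, known or untested is meant among the compounds shown, and "the series" means these compounds.

Working notes on the series.

The shared core is carried by compound 1 `c1ccc([C@H]2OC[C@H]([C@@H]3CCCCN3)O2)cc1`, compound 2 `C[C@]1(c2ccccc2)OC[C@H]([C@@H]2CCCCN2)O1` and compound 3 `CCC[C@]1(c2ccccc2)OC[C@H]([C@@H]2CCCCN2)O1`. In a functional assay (brain) for displacement of a labelled ligand, with Rattus norvegicus as the target (a lower number here means a stronger inhibitor, a higher number a weaker inhibitor), compound 1 gives 25000 nM, compound 2 gives 847 nM and compound 3 gives 69 nM, so compound 3 has the lowest number of the three. Among the compounds with values here, the one single-point step measured so far, a 12-fold lower number from compound 2 to compound 3 (1.09 log units; beyond the scatter), shows that lengthening the chain on the saturated ring carbon pays off. Compound 4 `CCCC[C@]1(c2ccccc2)OC[C@H]([C@@H]2CCCCN2)O1` continues this chain by methyl in place of hydrogen on a saturated chain carbon, three bonds along the chain from a saturated ring carbon. Compound 1 and compound 2 have no chain of this kind to compare with. Since the chain is already three carbons long in compound 3, a smaller gain than that step is expected, if any, for compound 4: a 1.7-fold lower number from compound 3 to compound 4 (0.24 log units; within the scatter), giving an estimated 40 nM with a range from 15 nM to 120 nM.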

Compound 4, inhibition constant: 200 nM
For compound 4 the middle estimate is 5.0-fold (0.70 log units) below the measured one; measured number above the stated range.
By their numbers in this assay, from the lowest: compound 3; then compound 4; then compound 2; then compound 1.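

In this assay the gain from lengthening the chain does not carry on from propyl to butyl: methyl in place of hydrogen, three bonds along the chain from the saturated ring carbon, gives a 2.9-fold higher number from compound 3 to compound 4 (0.46 log units; beyond the scatter). The butyl chain still keeps part of the earlier gain, with a 4.2-fold lower number from compound 2 to compound 4 (0.63 log units; beyond the scatter), so among these chains the response turns over, with compound 3 lowest. Nothing at hand accounts for this turn.

Open, going by these compounds, is how ethyl or pentyl would rank at this place. Also open, on these data alone, is whether a branched chain such as isobutyl would behave like butyl.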